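The source may hold more compounds than are shown below. What is called first, only, known or untested is meant among the compounds shown, and "the series" means these compounds.

Compound 1 `CCCCC/C=C\C[C@]1(O)C=CC(=O)/C1=C/C=C\CCCC(=O)OC` is the parent of this small set, and in a functional assay on PC-3 cells (Homo sapiens) for cytotoxicity, read by sulforhodamine B assay, with a stated time of 72 h (a higher number here means a weaker inhibitor, a lower number a stronger inhibitor), compound 1 gives 7200 nM. Compound 2 `CCCCC/C=C\C[C@@]1(O)C=C(Br)C(=O)/C1=C\C=C\CCCC(=O)OC` carries a bromine on a double-bonded ring carbon, and in this assay compound 2 gives 500 nM. Compound 3 `CCCCC/C=C\C[C@@]1(O)C=C(Cl)C(=O)/C1=C\C=C\CCCC(=O)OC` has a chlorine in that position; in this assay compound 3 gives 800 nM, the second highest of the three numbers, close to compound 2 and well below compound 1. For the measured compounds named here, the only single-point step so far is a 1.6-fold higher number from compound 2 to compound 3 (0.20 log units; within the scatter), a halogen swap that changes little.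

Compound 4 `CCCCC/C=C\C[C@@]1(O)C=C(Cl)C(=O)/C1=C/C=C/CCCC(=O)OC` keeps every atom and bond of compound 3: the two compounds have the same atoms and bonds and differ only in configuration as drawn: 1 of 4 stereo elements differ; a double bond is drawn Z in compound 3 and E in compound 4. Going by the values given here, no measured step concerns a change of double-bond geometry, so there is nothing to scale an expectation by; the halogen step gives no guidance here. The step of a 1.3-fold higher number from compound 3 to compound 4 (0.10 log units; within the scatter) is therefore expected to stay within the scatter. Compound 4 is estimated at 1000 nM, with a range from 350 nM to 3000 nM.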

Compound 4, half-maximal inhibitory concentration: 1900 nM
Beside the measured number, compound 4's estimate is 1.9-fold (0.28 log units) below it; measured number inside the range.
By their numbers in this assay, from the lowest: compounds 2 and 3 (each within the scatter of the next); then compound 4; then compound 1.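

Double-bond geometry counts for something in this series: in this assay the change from Z to E gives a 2.4-fold higher number from compound 3 to compound 4 (0.38 log units; beyond the scatter), a modest step. The halogen swap, a 1.6-fold higher number from compound 2 to compound 3 (0.20 log units; within the scatter), stayed within the scatter, whereas this step goes beyond it even though no atom enters or leaves. This step can be put down to the drawn geometry alone, because nothing else separates the pair: the fact that compounds 3 and 4 differ only in the configuration as drawn

As far as these compounds go, whether the bromine of compound 2 would respond to the same change of geometry in the same way remains open, as does the role of the other stereo elements. Also open, from the compounds shown here alone, is how a nitrile in place of the halogen, or a carboxylic acid in place of the methyl ester, would behave with either geometry.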